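Replacing the dichlorophenyl urea of compound 1 with a benzamide

The source may hold more compounds than are shown below. What is called first, only, known or untested is meant among the compounds shown, and "the series" means these compounds.

Compound 1 `COc1cc(-c2nn(-c3cccc(NC(=O)Nc4ccc(Cl)c(Cl)c4)c3)cc2-c2ccncc2)ccc1Cl` is the stronger of the two measured compounds in a functional assay on COLO 205 cells (Homo sapiens) for inhibition, read by sulforhodamine B assay, with a stated time of 48 h (on this read-out lower numbers stand for higher toxicity in this test and higher numbers for lower toxicity in this test), where compound 1 gives 3140 nM. Among the compounds with values here, its only measured neighbour, compound 2 `O=C(Nc1cccc(-n2cc(-c3ccncc3)c(-c3ccc(Cl)c(O)c3)n2)c1)Nc1ccc(Cl)c(Cl)c1`, gives 22700 nM in this assay, and the step of a 7.2-fold higher number from compound 1 to compound 2 (0.86 log units; beyond the scatter) comes from exchanging a methyl for hydrogen on the aromatic oxygen, a change at a different place from the one considered here. Compound 3 `COc1cc(-c2nn(-c3cccc(NC(=O)c4ccccc4)c3)cc2-c2ccncc2)ccc1Cl` differs from compound 1 by phenyl in place of (3,4-dichlorophenyl)amino on a carbonyl carbon, so the urea becomes a simple benzamide. Within the data shown here, no measured step touches this part of the molecule, so the expectation rests on the size of the one known step and on the loss of the chlorinated ring. A rise in the number, towards lower toxicity, is expected for compound 3, estimated at 15000 nM with a range of 4000 nM to 60000 nM, corresponding to an expected step of a 4.8-fold higher number from compound 1 to compound 3 (0.68 log units; beyond the scatter).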

Compound 3, concentration lethal to 50% of the cells: 68400 nM
For compound 3 the middle estimate is 4.6-fold (0.66 log units) below the measured one; measured number above the stated range.
By their numbers in this assay, from the lowest: compound 1; then compound 2; then compound 3.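

In this assay, the change from (3,4-dichlorophenyl)amino to phenyl on the carbonyl carbon gives a 22-fold higher number from compound 1 to compound 3 (1.34 log units; beyond the scatter), towards lower toxicity in this test. This is a large step, whereas the only earlier one, at the aromatic oxygen, was modest, so this second place on the molecule also strongly affects the number. The change removes the urea nitrogen with its hydrogen and both chlorine atoms at once, and nothing available explains the step.

On these data alone, it remains open whether the chlorine atoms or the urea nitrogen account for the rise. A 3,4-dichlorobenzamido group, which keeps the chlorines without that nitrogen, and a phenylurea, which keeps the nitrogen without the chlorines, would separate the two.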